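A few compounds are considered here, and "the series" means these few. Any claim that something is new, unique, unknown or untested is made for them only; others in the source may bear on it.

Compound 1 `CCCCCCNc1nc(-c2ccccc2)nc2c1nnn2Cc1ccccc1Cl` gives 31000000 nM in an assay on isolated protein for binding affinity to adenosine receptor A1 (Bos taurus); a lower number here means a stronger inhibitor, a higher number a weaker inhibitor. Compound 2 `CCCCCCNc1nc(-c2ccccc2)nc2c1nnn2Cc1ccccc1F`, which carries fluoro in place of chloro on an aromatic carbon, gives 25000000 nM in this assay, so the two differ only by a 1.2-fold lower number from compound 1 to compound 2 (0.09 log units; within the scatter). Compound 3 `COc1ccc(C(=O)Nc2nc(-c3ccccc3)nc3c2nnn3Cc2ccccc2Cl)cc1` differs from compound 1 by (4-methoxyphenyl)carbonyl in place of hexyl on a nitrogen on an aromatic ring. Within the data shown here, the single measured step touches another part of the shared core, so no measured step bears on this change, and no direction can be read from the data. Compound 3 is therefore estimated at 15000000 nM, within a range from 1000000 nM to 100000000 nM, which means an expected step of a 2.1-fold lower number from compound 1 to compound 3 (0.32 log units; beyond the scatter).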

Compound 3, inhibition constant: 20000000 nM
The estimate for compound 3 lay 1.3-fold (0.12 log units) below the measured number; measured number inside the range.
By their numbers in this assay, from the lowest: compounds 3, 2 and 1 (each within the scatter of the next).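

Putting (4-methoxyphenyl)carbonyl in place of hexyl on this nitrogen gives a 1.6-fold lower number from compound 1 to compound 3 (0.19 log units; within the scatter) in this assay. Among these compounds, this is the first look at this position: a chain without a ring and a group with an aromatic ring and a carbonyl give numbers within the scatter of each other. Nothing available explains this likeness.

As far as these compounds go, it remains open whether a shorter chain such as butyl, or a chain ending in a carboxylic acid, would move the number beyond the scatter. From the compounds shown here alone, the role of the methoxy group within the new group is also open.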